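The source may report more compounds than this note shows. Statements on the series, on what has been measured and on what is new or still open speak of the compounds shown alone.

Measured in a functional assay on MT4 cells (Homo sapiens); on this read-out higher numbers stand for lower toxicity in this test and lower numbers for higher toxicity in this test:
compound 1 `Cc1cn([C@@H]2O[C@H](CO[Si](C)(C)C(C)(C)C)[C@@]3(OS(=O)(=O)C=C3NCC(=O)O)[C@H]2O[Si](C)(C)C(C)(C)C)c(=O)n(C)c1=O`: 30000 nM
compound 2 `Cc1cn([C@@H]2O[C@H](CO[Si](C)(C)C(C)(C)C)[C@@]3(OS(=O)(=O)C=C3NCC(N)=O)[C@H]2O[Si](C)(C)C(C)(C)C)c(=O)n(C)c1=O`: 14900 nM
compound 3 `Cc1cn([C@@H]2O[C@H](CO[Si](C)(C)C(C)(C)C)[C@@]3(OS(=O)(=O)C=C3NCCC(=O)O)[C@H]2O[Si](C)(C)C(C)(C)C)c(=O)n(C)c1=O`: 11500 nM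

Compound 2 stands second highest of the three numbers; a 2.0-fold lower number from compound 1 to compound 2 (0.30 log units; within the scatter) and a 1.3-fold lower number from compound 2 to compound 3 (0.11 log units; within the scatter) are both within the scatter, so the three compounds are not separated by order. Only a 2.6-fold lower number from compound 1 to compound 3 (0.42 log units; beyond the scatter) reaches beyond it, and modestly.

Compound 4 `Cc1cn([C@@H]2O[C@H](CO[Si](C)(C)C(C)(C)C)[C@@]3(OS(=O)(=O)C=C3NCCC(=O)OCc3ccccc3)[C@H]2O[Si](C)(C)C(C)(C)C)c(=O)n(C)c1=O` differs from compound 2 by (benzyloxycarbonyl)methyl in place of carbamoyl on a saturated chain carbon bound to an amine nitrogen. For the measured compounds named here, the step bearing on it is a 1.3-fold lower number from compound 2 to compound 3 (0.11 log units; within the scatter), at the same place and within the scatter; no measured step introduces a ring at this place, so the effect of that part is unknown. The step of a 1.5-fold lower number from compound 2 to compound 4 (0.17 log units; within the scatter) is therefore expected to be small, with wide uncertainty. Compound 4 is estimated at 10000 nM, range 3000 nM to 35000 nM.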

Compound 4, half-maximal cytotoxic concentration: > 250000 nM
Compound 4 gave a limit, no number; the forecaster's own chance of this, stated with the estimate: 10%; middle value at least 25-fold (1.39 log units) from the limit.
By their numbers in this assay, from the lowest: compounds 3, 2 and 1 (each within the scatter of the next, the first and the last beyond it). At a limit, above all of these: compound 4.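

In this assay compound 4 gives a limit, not a number: the limit of > 250000 nM in this assay, at which 1 of the 4 values shown sits. On a saturated chain carbon bound to an amine nitrogen, (benzyloxycarbonyl)methyl gives an at least 16-fold higher number from compound 2 to compound 4 (1.22 log units; beyond the scatter) and an at least 8.3-fold higher number from compound 1 to compound 4 (0.92 log units; beyond the scatter), whereas the groups without a ring in compounds 1, 2 and 3 lie close together. Benzyl in place of hydrogen on an oxygen next to a carbonyl group gives an at least 21-fold higher number from compound 3 to compound 4 (1.33 log units; beyond the scatter), so this single change takes the read-out well outside that narrow spread.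

On these data alone, it remains open whether the benzyl ring or the ester itself carries this step; a methyl ester would separate the two. As far as these compounds go, the true size of the step also stays open, as compound 4 gives only a limit.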